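Replacing the benzyl group on the ring nitrogen of compound 1

The source may report more compounds than this note shows. Statements on the series, on what has been measured and on what is new or still open speak of the compounds shown alone.

Compound 1 has the structure `NC(=O)c1c(NC(=O)c2ccccc2Cl)sc2c1CCN(Cc1ccc(Cl)cc1)C2`. In a functional assay on HeLa cells (Homo sapiens) for antiproliferative activity, with a stated time of 24 h (a higher number here means a weaker inhibitor, a lower number a stronger inhibitor), compound 1 gives > 50000 nM, which is a limit of the assay and not a number. Compound 2, `NC(=O)c1c(NC(=O)c2ccc(C(F)(F)F)cc2)sc2c1CCN(Cc1ccc(Cl)cc1)C2`, carries 4-(trifluoromethyl)phenyl in place of 2-chlorophenyl on a carbonyl carbon. In this assay compound 2 gives > 50000 nM, again a limit of the assay. The step that the two limits leave unreadable from compound 1 to compound 2 therefore cannot be read, as the limit of > 50000 nM in this assay, at which 2 of the 2 values shown sit, shows. Compound 3, `NC(=O)c1c(NC(=O)c2ccccc2Cl)sc2c1CCN(C(=S)Nc1ccccc1F)C2`, differs from compound 1 at a different place: a group of 10 heavy atoms (7 carbon, 1 nitrogen, 1 fluorine, 1 sulfur; one six-membered aromatic ring of carbon only) in place of a group of 8 heavy atoms (7 carbon, 1 chlorine; one six-membered aromatic ring of carbon only), on an amine nitrogen in a ring. Going by the values given here, no measured step touches this position, so neither of the two measured compounds gives a direction or a size for the change from compound 1 to compound 3. Both measured compounds sit at the limit, so the only thing the data show is that the shared core with the 4-chlorobenzyl group has not yet given a readable inhibitor. Compound 3 is therefore expected at 50000 nM, within 10000 nM to 200000 nM, and this corresponds to an estimated step of a number no higher from compound 1 to compound 3 (the limit leaves the size open) that stays near the limit.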

Compound 3, half-maximal inhibitory concentration: 28700 nM
For compound 3 the middle estimate is 1.7-fold (0.24 log units) above the measured one, within the range that was stated.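

Going by these compounds alone, at the amine nitrogen in the ring, the change from 4-chlorobenzyl to the group of compound 3 gives the first number that can be read in this assay, where the other two compounds stay at a limit of the assay: the limit of > 50000 nM in this assay, at which 2 of the 3 values shown sit. On these data alone, measured against the limit of compound 1, this change gives an at least 1.7-fold lower number from compound 1 to compound 3 (0.24 log units; that floor lies within the scatter), so its true size stays open and the printed floor alone does not separate the two compounds. The entering group brings a double bond outside aromatic rings, a hydrogen-bond donor and a hydrogen-bond acceptor that 4-chlorobenzyl lacks, and this single exchange does not tell which of these features, if any, accounts for the readable value.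

The compounds shown leave open how a group with oxygen in place of the sulfur, a simple amide or a longer alkyl chain on this nitrogen would read in this assay. They also leave open whether 4-(trifluoromethyl)phenyl on the carbonyl carbon, which cannot be read with 4-chlorobenzyl on the nitrogen, would give a readable step alongside the group of compound 3.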